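A few compounds are considered here, and "the series" means these few. Any claim that something is new, unique, unknown or untested is made for them only; others in the source may bear on it.

Of the compounds shown here, two have been tested so far in a functional assay on NUGC-3 cells (Homo sapiens) for antiproliferative activity, read by sulforhodamine B assay; on this read-out higher numbers stand for weaker inhibition of growth and lower numbers for stronger inhibition of growth. Compound 1 `COc1cccc(OCCC(C)(C)C)c1C(=O)/C=C/c1ccc(O)cc1` gives > 30000 nM, which is a limit of the assay and not a number. Compound 2 `CC(C)=CCOc1cccc(O)c1C(=O)/C=C/c1ccc(O)cc1` gives > 30000 nM, again only a limit. Compound 2 therefore stands at the limit of > 30000 nM in this assay, at which 2 of the 2 values shown sit, with no number to show how far it is from activity. Compound 3 `O=C(/C=C/c1ccc(O)cc1)c1c(O)cccc1OCC1CCCC1` keeps the shared core and carries cyclopentyl in place of 2-methylprop-1-en-1-yl on a saturated chain carbon bound to an oxygen on an aromatic ring. Among the compounds with values here, no measured step between compounds is available as a guide, so little or nothing beyond the scatter is expected in this assay, with any change leaning towards slightly stronger inhibition. The expected step is an at least 1.2-fold lower number from compound 2 to compound 3 (0.07 log units; that floor lies within the scatter). For compound 3 the estimated value is 25000 nM, with an expected range from 8000 nM to 60000 nM.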

Compound 3, concentration for 50% growth inhibition: 2140 nM
Compound 3: the middle estimate sits 12-fold (1.07 log units) above what was measured, outside the stated range (below it).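

Swapping (3-methylbut-2-en-1-yl)oxy for cyclopentylmethoxy gives, in this assay, an at least 14-fold lower number from compound 2 to compound 3 (1.14 log units; beyond the scatter). Within the data shown here, this shows that the group at this place can decide whether growth inhibition is seen at all, and compound 3 gives the first true number in the set, 2140 nM. Compound 2 gives > 30000 nM, which is a limit and not a number, so the step has a known minimum but no known full size: the limit of > 30000 nM in this assay, at which 2 of the 3 values shown sit.

The single swap adds a ring, removes a double bond and changes the size of the group all at once, and the compounds shown cannot tell which of these matters. A saturated open chain such as 3-methylbutoxy, or a larger ring as in cyclohexylmethoxy, at the same place would begin to separate these possibilities.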